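Chloro to trifluoromethyl on the shared core: working notes

This account rests on a few compounds, and the source may have more. Where it says the series, first, only, none or still open, it means among the compounds named here.

In a functional assay on the whole organism for positive allosteric modulation, with Mus musculus as the target (on this read-out higher numbers stand for an effect only at larger amounts of compound and lower numbers for an effect already at smaller amounts), compound 1 `CCC(=O)N(c1cccc(C)c1)C1CCCC1N(C)C` gives 3 mg/kg; 3 mg/kg (2 entries) in two matching entries. Going by the values given here, compound 2 `CCC(=O)N(c1cccc(Cl)c1)C1CCCC1N(C)C` gives 0.4 mg/kg as its only number, the lower of the two values shown, and one further entry for it carries no single number. Compound 3 `CCC(=O)N(c1cccc(C(F)(F)F)c1)C1CCCC1N(C)C` is still unmeasured in this assay and has trifluoromethyl in place of chloro on an aromatic carbon. Among the compounds with values here, no measured step covers this change, so the expectation is only a judgement: a small move toward a larger dose, at about the edge of the usual scatter. The range is kept wide, since compound 1 at 3 mg/kg; 3 mg/kg (2 entries) and compound 2 at 0.4 mg/kg show how far apart two members of the series can lie with different groups on that aromatic carbon. This estimate means an expected change (a 2.0-fold higher number from compound 2 to compound 3 (0.30 log units; within the scatter)). For compound 3 the expected value is 0.8 mg/kg with an estimated range from 0.25 mg/kg to 2.5 mg/kg in this assay.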

Compound 3, dose for half-maximal effect: 0.3 mg/kg
Estimate against measurement, compound 3: 2.7-fold (0.43 log units) above; the measured number falls inside the stated range.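

In this assay, trifluoromethyl in place of chloro on this aromatic carbon gives a 1.3-fold lower number from compound 2 to compound 3 (0.12 log units; within the scatter), so the count of heavy atoms at this place rises from 1 to 4 with no change that can be told from the scatter. Going by these compounds alone, the earlier values showed only that the group on this carbon can matter, with compound 1, which carries methyl, at 3 mg/kg; 3 mg/kg (2 entries) and compound 2 at 0.4 mg/kg; this step adds a pair of different groups that the read-out does not separate. Nothing measured on these groups bears on why the two read alike.

The compounds shown leave open how a nitrile, a methoxy group or an amine on this aromatic carbon would read, and so whether the agreement between chloro and trifluoromethyl extends to any other group there. Within the data shown here, they also give no step at any other place on the shared core, such as a longer acyl chain on the amide nitrogen or a primary amine in place of dimethylamino, so this reading holds for this one aromatic carbon alone.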